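Carboxylic Acid to Hydroxamic Acid on a Cyclopropyl

The source may hold more compounds than are shown below. What is called first, only, known or untested is meant among the compounds shown, and "the series" means these compounds.

Compound 1 `O=C(O)CCCc1ccc(NCc2cccc(Oc3ccccc3)c2)cc1`: 1120 nM
Compound 2 `Cc1nc(-c2ccc(C(F)(F)F)cc2)sc1CNc1ccc([C@H]2C[C@@H]2C(N)=O)cc1`: 4.47 nM
Compound 3 `Cc1nc(-c2ccc(C(F)(F)F)cc2)sc1CNc1ccc([C@H]2C[C@@H]2C(=O)N(C)C)cc1`: 66.1 nM

In a functional assay on CHO cells for agonist activity at Free fatty acid receptor 1 (Homo sapiens) (a higher number here means that more compound is needed for the effect, a lower number that less compound is needed), compound 1 gives the highest number of the three; compound 3 and compound 2 both need far less compound, and both gaps lie beyond the scatter. Compound 4 `O=C(NO)[C@H]1C[C@@H]1c1ccc(NCc2cccc(Oc3ccccc3)c2)cc1` differs from compound 1 by 2-(hydroxycarbamoyl)cyclopropyl in place of 3-carboxypropyl on an aromatic carbon. Among the compounds with values here, no measured step covers this exchange directly. The nearest comparison is the amide pair, a 15-fold higher number from compound 2 to compound 3 (1.17 log units; beyond the scatter), which shows that the group on the carbonyl of this cyclopropyl unit matters greatly. Compound 2, with the unsubstituted amide, is the most potent compound here, and the hydroxycarbamoyl group of compound 4 stands closer to it than to the dimethylamide. A lower number is therefore expected for compound 4, estimated as a 3.7-fold lower number from compound 1 to compound 4 (0.57 log units; beyond the scatter). Compound 4 is estimated at 300 nM, within a range from 60 nM to 1500 nM.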

Compound 4, half-maximal effective concentration: 14.8 nM
Beside the measured number, compound 4's estimate is 20-fold (1.31 log units) above it, and the stated range ends above it.
By their numbers in this assay, from the lowest: compound 2; then compound 4; then compound 3; then compound 1.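

In this assay, 2-(hydroxycarbamoyl)cyclopropyl in place of 3-carboxypropyl on the aromatic carbon gives a 76-fold lower number from compound 1 to compound 4 (1.88 log units; beyond the scatter), so this position on the core of compound 1 has a strong effect on the number. The earlier amide pair varied only the group on the carbonyl, whereas this step changes the chain and its end group together. What the compounds shown leave open is how the step divides between the two changes, which a cyclopropyl carrying a carboxylic acid on the same core could help separate. No measurement at hand accounts for the step.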